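Fluoro to chloro on the bromo compound

The source may report more compounds than this note shows. Statements on the series, on what has been measured and on what is new or still open speak of the compounds shown alone.

Compounds with a shared core have been read in an ADME assay on HaCaT cells (Homo sapiens) for cytotoxicity, read by MTT assay, with a stated time of 48 h (a higher number here means a weaker inhibitor, a lower number a stronger inhibitor), so far. Compound 1 `Fc1ccc(-c2nn(-c3ccccc3)cc2-c2nc3cc(F)ccc3[nH]2)cc1` gives > 50000 nM as a limit. Compound 3 `Cc1ccc2[nH]c(-c3cn(-c4ccccc4)nc3-c3ccc(F)cc3)nc2c1` gives > 50000 nM as a limit too. For the measured compounds named here, compound 2 `Fc1ccc(-c2nn(-c3ccccc3)cc2-c2nc3cc(Br)ccc3[nH]2)cc1` gives 21800 nM as the only true number of the three.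

Compound 4 `Clc1ccc(-c2nn(-c3ccccc3)cc2-c2nc3cc(Br)ccc3[nH]2)cc1` follows from compound 2 through chloro in place of fluoro on an aromatic carbon and so reads chloro in place of fluoro on an aromatic carbon, with 4-fluorophenyl becoming 4-chlorophenyl. Going by the values given here, no measured step touches this group. The nearest evidence is an at least 2.2-fold lower number from compound 1 to compound 2 (0.36 log units; beyond the scatter) and an at least 2.2-fold higher number from compound 2 to compound 3 (0.36 log units; beyond the scatter) on another carbon, and both are read against the limit of > 50000 nM in this assay, at which 2 of the 3 values shown sit, in the same way. They therefore give no direct size for this change. Compound 4 keeps the bromo of compound 2 and its 21800 nM anchors the expectation. An estimated 1.2-fold lower number from compound 2 to compound 4 (0.08 log units; within the scatter) is expected in this assay with no step beyond the scatter. For compound 4 the estimate is 18000 nM with an expected range from 8000 nM to 42000 nM as the working figure.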

Compound 4, half-maximal inhibitory concentration: > 50000 nM
Compound 4: a limit, no number; the forecaster's own chance of this, stated with the estimate: 15%; middle value at least 2.7-fold (0.44 log units) from the limit.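

In this assay, the change from 4-fluorophenyl to 4-chlorophenyl on the bromo compound gives an at least 2.2-fold higher number from compound 2 to compound 4 (0.36 log units; beyond the scatter). For the compounds shown here, this is the first reading at this position, on the aromatic carbon para to a large group, and it shows that the group here matters in this assay, not only the group on the other ring carbon changed in the earlier steps. The step is a bound and not a size, and compound 2 remains the only compound with a true number, with the rest of the series at a single limit: the limit of > 50000 nM in this assay, at which 3 of the 4 values shown sit.

From the compounds shown here alone, how the same chloro for fluoro change reads with the methyl of compound 3 in place of the bromo remains open. Also open, going by these compounds, is whether a methoxy group or an amine at this position would give a true number.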